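Chloro for Cyano on the Benzyl Group of Compound 2

The source may hold more compounds than are shown below. What is called first, only, known or untested is meant among the compounds shown, and "the series" means these compounds.

Compound 1 `Cc1nn(-c2ncnc3nc[nH]c23)c2c1C(OCC(=O)c1ccc(F)cc1)CC(=O)N2` gives 973 nM in a functional assay on HEK293 cells for agonist activity at G-protein coupled receptor 39 (Homo sapiens), read by scintillation proximity assay and inositol phosphate accumulation, with a stated time of 75 min; a lower number here means that less compound is needed, a higher number that more compound is needed for the effect; compound 2 `Cc1nn(-c2ncnc3nc[nH]c23)c2c1C(OCc1ccccc1C#N)CC(=O)N2` gives 127 nM; compound 3 `Cc1nn(-c2ncnc3nc[nH]c23)c2c1C(C(=O)N(C)c1ccccc1)CC(=O)N2` gives 5220 nM.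

Compound 2 holds the lowest number of the three, with a 7.7-fold lower number from compound 1 to compound 2 (0.88 log units; beyond the scatter) and a 41-fold higher number from compound 2 to compound 3 (1.61 log units; beyond the scatter) both beyond the scatter. Compound 4 `Cc1nn(-c2ncnc3nc[nH]c23)c2c1C(OCc1ccccc1Cl)CC(=O)N2` differs from it by chloro in place of cyano on an aromatic carbon. Neither measured step touches this spot: each replaces the whole group on the saturated ring carbon rather than a substituent on the aromatic ring, so neither bears directly on the change. With nothing pointing either way, the expected step is a 1.3-fold higher number from compound 2 to compound 4 (0.10 log units; within the scatter), within the scatter. Compound 4 is therefore estimated at 160 nM, in a range from 50 nM to 500 nM.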

Compound 4, half-maximal effective concentration: 47 nM
Beside the measured number, compound 4's estimate is 3.4-fold (0.53 log units) above it; the whole stated range lies above it.
By their numbers in this assay, from the lowest: compound 4; then compound 2; then compound 1; then compound 3.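

Going by these compounds alone, there is a 2.7-fold lower number from compound 2 to compound 4 (0.43 log units; beyond the scatter) when chloro replaces cyano, so this small swap on the aromatic ring, which no earlier step touched, matters in this assay and is not lost in the scatter. Compound 4 now holds the lowest number of the four, with a 110-fold lower number from compound 3 to compound 4 (2.05 log units; beyond the scatter) and a 21-fold lower number from compound 1 to compound 4 (1.32 log units; beyond the scatter) for the larger replacements. Nothing available explains why chloro gives the lower number.

Going by these compounds, whether bromo, methyl or methoxy at this spot would give a lower number still remains open. So does whether chloro elsewhere on the aromatic ring would give a similar number.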